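The compounds below may be only part of what the source reports. "The series", "measured", "known", "first", "only" and "open" are said of these compounds alone.

Of the compounds shown here, three sharing one core have been measured in a functional assay for antagonist activity at P2X purinoceptor 7 (Homo sapiens), read by FLIPR and calcium flux; a lower number here means a stronger inhibitor, a higher number a weaker inhibitor. Compound 1 `Cc1ccccc1CNc1ncnn1-c1cccc(Cl)c1Cl` gives 20.9 nM. Compound 2 `Clc1cccc(-n2ncnc2NCc2cccnc2)c1Cl` gives 117 nM, and the step from one to the other is a 5.6-fold higher number from compound 1 to compound 2 (0.75 log units; beyond the scatter). Compound 3 `Clc1cccc(-n2ncnc2NCc2cccnc2N2CCC2)c1Cl` gives 9.12 nM, reached by a step of a 13-fold lower number from compound 2 to compound 3 (1.11 log units; beyond the scatter). Compound 3 therefore holds the lowest number of the three, with compound 1 the nearest to it and compound 2 the furthest away.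

Compound 4 `Clc1cccc(-n2ncnc2NCc2cccnc2-c2ccsc2)c1Cl` differs from compound 3 in one place: thiophen-3-yl in place of azetidin-1-yl on an aromatic carbon. For the measured compounds named here, the only measured step that bears on this position is the one from compound 2 to compound 3, where filling the same position was worth a 13-fold lower number from compound 2 to compound 3 (1.11 log units; beyond the scatter). Whether an aromatic ring at that position keeps that gain is not shown by the measured compounds, so the expectation for compound 4 is a modest loss, a 2.7-fold higher number from compound 3 to compound 4 (0.44 log units; beyond the scatter), with a wide range. Compound 4 is estimated at 25 nM in this assay, between 6 nM and 100 nM.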

Compound 4, half-maximal inhibitory concentration: 15.1 nM
For compound 4 the middle estimate is 1.7-fold (0.22 log units) above the measured one; the range from low to high includes it.
By their numbers in this assay, from the lowest: compounds 3, 4 and 1 (each within the scatter of the next, the first and the last beyond it); then compound 2.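

In this assay, putting the aromatic thiophen-3-yl in place of the non-aromatic azetidin-1-yl gives a 1.7-fold higher number from compound 3 to compound 4 (0.22 log units; within the scatter), so these two groups cannot be told apart here. Thiophen-3-yl in place of hydrogen also gives a 7.7-fold lower number from compound 2 to compound 4 (0.89 log units; beyond the scatter), which shows that the improvement at this position does not require azetidin-1-yl, its four-membered non-aromatic ring or its nitrogen. No measurement shown explains why either group improves on hydrogen.

Both groups shown at this position are rings, so it remains open whether an open-chain group such as methoxy or dimethylamino would keep the improvement. Six-membered rings such as phenyl or morpholin-4-yl are equally untested among the compounds shown.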